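Working notes: from compound 3 to compound 4

The source may report more compounds than this note shows. Statements on the series, on what has been measured and on what is new or still open speak of the compounds shown alone.

Values in a functional assay on A549 cells (Homo sapiens) for antiproliferative activity, read by MTT assay, with a stated time of 48 h; a higher number here means a weaker inhibitor, a lower number a stronger inhibitor:
- compound 1 `Cc1ccc(/C=C/C(=O)Nc2nnc(-c3ccc(Cl)cc3)s2)cc1` gives 1.25 ug/mL
- compound 2 `O=C(/C=C/c1ccc(C(F)(F)F)cc1)Nc1nnc(-c2ccccc2)s1` gives 1.78 ug/mL
- compound 3 `COc1ccc(/C=C/C(=O)Nc2nnc(-c3ccccc3)s2)cc1` gives 0.76 ug/mL

In this assay compound 3 stands at 0.76 ug/mL, within the scatter of compound 1 and clearly apart from compound 2. Compound 4 `Cc1ccc(/C=C/C(=O)Nc2nnc(-c3ccccc3)s2)cc1`, not yet measured, has methyl in place of methoxy on an aromatic carbon, para to a large group: methyl in place of methoxy on an aromatic carbon.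

Among the compounds with values here, only one measured step bears directly on this carbon: a 2.3-fold lower number from compound 2 to compound 3 (0.37 log units; beyond the scatter), a modest change with methoxy in place of trifluoromethyl. Within the data shown here, no measured step swaps methoxy for methyl directly. Compound 1 also carries 4-methylphenyl and gives 1.25 ug/mL, but it differs from compound 4 elsewhere too, so it is only a loose guide.

A slightly higher number is expected in this assay, with no move beyond the scatter: the expected step is a 1.4-fold higher number from compound 3 to compound 4 (0.14 log units; within the scatter). The estimate for compound 4 is 1.05 ug/mL, with an expected range of 0.55 ug/mL to 2 ug/mL.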

Compound 4, half-maximal inhibitory concentration: 1.58 ug/mL
For compound 4 the middle estimate is 1.5-fold (0.18 log units) below the measured one; low and high end bracket the measured number.
By their numbers in this assay, from the lowest: compounds 3, 1, 4 and 2 (each within the scatter of the next, the first and the last beyond it).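

In this assay, the change from 4-methoxyphenyl to 4-methylphenyl gives a 2.1-fold higher number from compound 3 to compound 4 (0.32 log units; beyond the scatter) and thus puts a direct swap at this carbon on record, with methoxy holding the lower number. Methyl and trifluoromethyl do not separate at this carbon, as a 1.1-fold lower number from compound 2 to compound 4 (0.05 log units; within the scatter) shows, so among the three groups here only methoxy stands apart. With 4-methylphenyl kept, hydrogen in place of chloro on an aromatic carbon gives a 1.3-fold higher number from compound 1 to compound 4 (0.10 log units; within the scatter) and so leaves the two compounds unseparated.

On these data alone, whether an amine or a hydroxyl group at this carbon would stand with methoxy or with methyl remains open, as does the effect of a longer chain such as ethoxy. Nothing on hand explains why methoxy separates from methyl in this series.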